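Swapping a Cyclopropyl for a Chlorothiophene

The source may hold more compounds than are shown below. What is called first, only, known or untested is meant among the compounds shown, and "the series" means these compounds.

Two compounds share a core in which a hydrazide-urea chain links a fused bicyclic ring system to a chlorinated pyridine. Compound 1 `COc1cc(NC(=O)NNc2cc(-c3ccccc3)c3cnn(C)c3n2)cc(Cl)n1` carries a phenyl group on that bicyclic core; in an assay on isolated protein for binding affinity to sphingosine 1-phosphate receptor 2 (Homo sapiens), read by surface plasmon resonance (on this read-out lower numbers stand for tighter binding and higher numbers for weaker binding), compound 1 gives 3640 nM. Compound 2 `Cc1nn(C)c2nc(NNC(=O)Nc3cc(Cl)nc(Cl)c3)cc(C3CC3)c12` carries a cyclopropyl group at the same position and a differently substituted pyridine; in this assay compound 2 gives 3650 nM. The two numbers sit so close that the usual scatter of the measurement does not separate them. Compound 3 `Cc1nn(C)c2nc(NNC(=O)Nc3cc(Cl)nc(Cl)c3)cc(-c3ccc(Cl)s3)c12` differs from compound 2 in one place: 5-chlorothiophen-2-yl in place of cyclopropyl on an aromatic carbon. Within the data shown here, no measured pair isolates this change. Since compound 1 already shows that a flat aromatic ring at this position gives 3640 nM, the step of a 1.5-fold lower number from compound 2 to compound 3 (0.16 log units; within the scatter) is expected to be small and slightly toward tighter binding. Compound 3 is therefore estimated at 2500 nM, within a range from 800 nM to 8000 nM.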

Compound 3, dissociation constant: 1980 nM
For compound 3 the middle estimate is 1.3-fold (0.10 log units) above the measured one, within the range that was stated.
By their numbers in this assay, from the lowest: compounds 3, 1 and 2 (each within the scatter of the next).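

In this assay, among these compounds, the step of a 1.8-fold lower number from compound 2 to compound 3 (0.27 log units; within the scatter) is the first reading at this position in which nothing else in the molecule differs, since compound 1 differs from compound 2 in more than one place. At this aromatic carbon, a three-membered non-aromatic ring of carbon only and a five-membered aromatic ring carrying chlorine and sulfur therefore give numbers that the usual scatter cannot separate. So this change, large as it is in the atoms it adds, produces no reliable difference in binding in this assay, and nothing measured here explains why the two groups read alike.

From the compounds shown here alone, it remains open whether an amine, a carboxylic acid or a longer carbon chain at this carbon would move the number beyond the scatter. The same question holds for the unsubstituted thiophene, which would show whether the chlorine on the ring matters at all.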